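Methoxyphenyl Placement in the Imidazopyrazine Series: Notes

A few compounds are considered here, and "the series" means these few. Any claim that something is new, unique, unknown or untested is made for them only; others in the source may bear on it.

Measured so far in a functional assay on NCI-H522 cells (Homo sapiens) for inhibition, read by sulforhodamine B assay, with a stated time of 48 h, tested at 10 uM; a higher number here means more inhibition at the concentration tested (going by the name of the read-out), a lower number less inhibition:
Compound 1, `COc1ccc(-c2cn3ccnc3c(-c3ccc4ncn(C5CCCCC5)c4c3)n2)cc1`: -20.9%
Compound 2, `CC(=O)c1ccc(-c2cn3ccnc3c(-c3ccc4ncn(C5CCCCC5)c4c3)n2)cc1`: 10.4%

For the measured compounds named here, compound 1 gives the lowest of the two numbers; its nearest neighbour is compound 2, and the step of a number 31.3 percentage points higher from compound 1 to compound 2 (beyond the scatter) is the only measured step in the set. That step exchanges the group itself, acetyl in place of methoxy on an aromatic carbon, and says nothing about where a methoxyphenyl group is attached.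

Compound 3, `COc1ccccc1-c1cn2ccnc2c(-c2ccc3ncn(C4CCCCC4)c3c2)n1`, keeps every atom of compound 1 and differs only in the arrangement: 2-methoxyphenyl in place of 4-methoxyphenyl on an aromatic carbon. Going by the values given here, no measured step covers this kind of rearrangement, so the one known step can be taken only as a guide to how far a single change at this position has moved the number so far, not as a direction. The expectation is therefore a number close to that of compound 1, with a range wide enough to allow a shift of the size already seen: for compound 3 the estimate is -8%, between -35% and 20%, which means an expected step of a number 12.9 percentage points higher from compound 1 to compound 3 (beyond the scatter).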

Compound 3, a percentage reported as inhibition, at one concentration (the size of the read-out at that concentration, not a potency): 22.2%
Compound 3: middle estimate off by 30.2 percentage points, on the low side; the whole stated range lies below it.
By their numbers in this assay, from the lowest: compound 1; then compound 2; then compound 3.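

In this assay, the step of a number 43.1 percentage points higher from compound 1 to compound 3 (beyond the scatter) comes from 2-methoxyphenyl in place of 4-methoxyphenyl, with the same atoms joined differently. The earlier step had shown only that exchanging the group moves the number; this one shows that the arrangement within a methoxyphenyl group attached at this position can also move it beyond the scatter. The step of a number 11.8 percentage points higher from compound 2 to compound 3 (beyond the scatter), from 2-methoxyphenyl in place of 4-acetylphenyl, places compound 3 highest of the three and shows that the low number of compound 1 does not go with a methoxy group wherever it stands on the phenyl ring. Nothing available gives a reason for the difference between the two arrangements.

The compounds shown leave open whether an acetyl group arranged as the methoxy is in 2-methoxyphenyl would also give a higher number than 4-acetylphenyl, and whether the gain holds with an ethoxy group, an amine or a carboxylic acid there in place of methoxy. These are also readings at a single concentration, so they leave open how the compounds compare in potency.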